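The source may report more compounds than this note shows. Statements on the series, on what has been measured and on what is new or still open speak of the compounds shown alone.

Compound 1 `COc1ccc(S(=O)(=O)NC(=O)Nc2ccc(Cl)cc2)s1`, compound 2 `CCOc1ccc(S(=O)(=O)NC(=O)Nc2ccc(Cl)cc2)s1` and compound 3 `Cc1cc(S(=O)(=O)NC(=O)Nc2ccc(Cl)cc2)sc1C` were examined in a functional assay on the whole organism (6C3HED cells, Mus musculus) for inhibition, at a dose of 300 mg/kg by the oral route; on this read-out higher numbers stand for more inhibition at the one dose given (going by the name of the read-out) and lower numbers for less inhibition. In this assay compound 1 gives 100%, compound 2 gives 96% and compound 3 gives 73%. Compound 1 and compound 2 differ by methyl in place of hydrogen on a saturated chain carbon bound to an oxygen on an aromatic ring, and this change gave a number 4 percentage points lower from compound 1 to compound 2 (within the scatter). The cores of compound 1 and compound 3 differ by 4,5-dimethylthiophen-2-yl in place of 5-methoxythiophen-2-yl on a sulfonyl sulfur, a change that gave a number 27 percentage points lower from compound 1 to compound 3 (beyond the scatter) and leaves compound 3 with the lowest of the three numbers. Compound 4 `CCc1sc(S(=O)(=O)NC(=O)Nc2ccc(Cl)cc2)cc1C` has not yet been measured; it differs from compound 3 by methyl in place of hydrogen on a saturated chain carbon bound to an aromatic carbon. This is the same kind of change as that between compound 1 and compound 2, but not the same: there the entering methyl sits on a saturated chain carbon bound to an oxygen on an aromatic ring, here on a saturated chain carbon bound to an aromatic carbon. Since the earlier step of this kind was a number 4 percentage points lower from compound 1 to compound 2 (within the scatter), for compound 4 the expectation is a number 3 percentage points lower from compound 3 to compound 4 (within the scatter). Compound 4 is therefore estimated at 70% in this assay, with a range from 50% to 88%.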

Compound 4, a percentage reported as inhibition, in the whole organism at one dose (the size of the read-out at that dose, not a potency): 58%
Compound 4: middle estimate off by 12 percentage points, on the high side, and the stated range covers the measured number.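

In this assay, methyl in place of hydrogen on a saturated chain carbon bound to an aromatic carbon gave a number 15 percentage points lower from compound 3 to compound 4 (beyond the scatter), so on this core the change carries a cost larger than the usual scatter. Set beside the earlier step, it cannot be told apart from that step, and the series gives no ground for treating the change as differing in size from one core to the other: the same change on two cores in this assay, a number 4 percentage points lower (within the scatter) from compound 1 to compound 2 and a number 15 percentage points lower (beyond the scatter) from compound 3 to compound 4, 11 percentage points apart, within the scatter of two such steps. Within the data shown here, this does not show that the change carries over reliably, since there are only two pairs, the entering methyl sits in a different place in each, and only the step on the core of compound 3 lies beyond the scatter.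

The compounds shown leave open what a longer chain such as propyl, or an amine or a carboxylic acid, would do on that same saturated chain carbon. They also leave open how any of these compounds would behave at another dose or by another route.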